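A few compounds are considered here, and "the series" means these few. Any claim that something is new, unique, unknown or untested is made for them only; others in the source may bear on it.

Measured in a physicochemical assay for lipophilicity, read by HPLC, at pH 7.4; a lower number here means a more polar compound, a higher number a more lipophilic compound
- compound 1 `CNCc1cn(S(=O)(=O)c2ccccn2)c(-c2cccnc2F)c1F` gives 0.44
- compound 2 `CNCc1cn(S(=O)(=O)c2cnccc2C)c(-c2cccnc2F)c1F` gives 0.43

Compound 2 at 0.43 stands level with compound 1 within the scatter. Compound 3 `CNCc1cn(S(=O)(=O)c2ccc(C)nc2)c(-c2cccnc2F)c1F` carries 6-methylpyridin-3-yl in place of 4-methylpyridin-3-yl on a sulfonyl sulfur. Within the data shown here, the only measured step on that sulfur is a number 0.01 log units lower from compound 1 to compound 2 (within the scatter) and it put 4-methylpyridin-3-yl in place of pyridin-2-yl. Among the measured compounds shown here, with that step as the only guide, the estimate is a number 0.02 log units higher from compound 2 to compound 3 (within the scatter) in this assay and no step beyond the scatter is expected. For compound 3 the expected value is 0.45 with an estimated range from 0.15 to 0.8 for the coming measurement.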

Compound 3, distribution coefficient: 0.62
For compound 3 the middle estimate is 0.17 log units below the measured one; low and high end bracket the measured number.
By their numbers in this assay, from the lowest: compounds 2, 1 and 3 (each within the scatter of the next).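

In this assay, 6-methylpyridin-3-yl in place of 4-methylpyridin-3-yl on the sulfonyl sulfur gives a number 0.19 log units higher from compound 2 to compound 3 (within the scatter), and the same group in place of pyridin-2-yl gives a number 0.18 log units higher from compound 1 to compound 3 (within the scatter). Even an exchange that keeps the same atoms and joins them differently therefore yields no step beyond the scatter at this position, so all three pyridine groups remain level. Nothing on hand accounts for these steps.

Open, going by these compounds, is whether a different group on the sulfonyl sulfur, such as a phenyl ring bearing a carboxylic acid or an aminoethyl chain, would give a step beyond the scatter in this assay.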